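Swapping acetyl for dimethylamino on a pyrazole-linked scaffold

This account rests on a few compounds, and the source may have more. Where it says the series, first, only, none or still open, it means among the compounds named here.

Measured compounds:
- Compound 1 `COc1cc(C)cc(-c2c(-c3ccnc(-c4ccc(C(C)=O)cc4)c3)cnn2CC#N)c1`: 92%
- Compound 2 `COc1cc(C)cc(-c2nn(CC#N)cc2-c2ccnc(-c3ccc(N(C)C)cc3)c2)c1`: 44%

Of the compounds shown here, two have been tested in a functional assay on SN12C cells (Homo sapiens) for cytotoxicity, read by sulforhodamine B assay, with a stated time of 48 h, tested at 100 nM; on this read-out lower numbers stand for a stronger effect and higher numbers for a weaker effect at the one concentration tested. Compound 1 gives 92% in this assay, the higher of the two numbers. Going by the values given here, compound 2 carries the same dimethylamino-bearing ring on a differently connected core and gives 44%, a number well beyond the scatter away from compound 1; no single-point step separates these two, so only the two values themselves are known.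

Compound 3 `COc1cc(C)cc(-c2c(-c3ccnc(-c4ccc(N(C)C)cc4)c3)cnn2CC#N)c1` has not been measured. It differs from compound 1 in one place: dimethylamino in place of acetyl on an aromatic carbon. Since compound 2, which also carries dimethylamino, gives 44%, a downward step from compound 1 to compound 3 is expected, estimated as a number 37 percentage points lower from compound 1 to compound 3 (beyond the scatter), beyond the scatter. Compound 3 is therefore estimated at 55% in this assay, within a range from 35% to 85%.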

Compound 3, a percentage reported as activity, at one concentration (the size of the read-out at that concentration, not a potency): 28%
Beside the measured number, compound 3's estimate is 27 percentage points above it, and the stated range ends above it.
By their numbers in this assay, from the lowest: compound 3; then compound 2; then compound 1.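

In this assay, dimethylamino in place of acetyl on an aromatic carbon, para to a large group, gives a number 64 percentage points lower from compound 1 to compound 3 (beyond the scatter). Compound 1 and compound 2 differ in more than one place, so they could not tie any change in the read-out to this position; with the core held constant, this single exchange now accounts for a large step on its own. No evidence is available that explains the step.

The compounds shown leave open whether this step is particular to dimethylamino or would also appear with another group at this position, such as a primary amine, a morpholine or a carboxylic acid. They also leave open whether it would hold at other concentrations or in other cell lines.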